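Swapping the acyl chain on an aryl sulfonate amide

A few compounds are considered here, and "the series" means these few. Any claim that something is new, unique, unknown or untested is made for them only; others in the source may bear on it.

Measured so far:
Compound 1, `CCC(=O)Nc1ccc(S(=O)(=O)Oc2ccccc2C(C)C)cc1`: 7400 nM
Compound 2, `CC(C)C(=O)Nc1ccc(S(=O)(=O)Oc2ccccc2C(C)C)cc1`: 14000 nM

The two compounds share a core and differ only in the group on the carbonyl carbon of the amide. In a functional assay on HT-29 cells (Homo sapiens) for antiproliferative activity, read by sulforhodamine B assay, with a stated time of 48 h (a lower number here means a stronger inhibitor, a higher number a weaker inhibitor), compound 2 gives 14000 nM, the higher of the two numbers measured; its nearest neighbour is compound 1, and the step of a 1.9-fold higher number from compound 1 to compound 2 (0.28 log units; within the scatter) stays within the scatter, so the two values cannot be told apart.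

Compound 3, `CC(C)c1ccccc1OS(=O)(=O)c1ccc(NC(=O)CCCl)cc1`, has not been measured. It differs from compound 2 by 2-chloroethyl in place of isopropyl on a carbonyl carbon. No measured step involves a chlorine-bearing chain, so nothing shown bears directly on this swap. Going by the values given here, the only step available, a 1.9-fold higher number from compound 1 to compound 2 (0.28 log units; within the scatter), shows that changing the group on this carbonyl carbon moved the number only within the scatter. On that basis the step of a 1.6-fold lower number from compound 2 to compound 3 (0.19 log units; within the scatter) is expected to be small, with no clear direction. Compound 3 is therefore expected to give about 9000 nM in this assay, within a range of 3000 nM to 27000 nM.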

Compound 3, half-maximal inhibitory concentration: 16000 nM
Estimate against measurement, compound 3: 1.8-fold (0.25 log units) below; measured number inside the range.
By their numbers in this assay, from the lowest: compounds 1, 2 and 3 (each within the scatter of the next, the first and the last beyond it).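

In this assay the isopropyl and 2-chloroethyl groups on this carbonyl carbon cannot be told apart (a 1.1-fold higher number from compound 2 to compound 3 (0.06 log units; within the scatter)), so a chlorine-bearing chain of 3 heavy atoms can stand where a branched carbon group of the same heavy-atom count stood with no readable effect on the number. The comparison with compound 1 is the only one of the three that passes the scatter (a 2.2-fold higher number from compound 1 to compound 3 (0.33 log units; beyond the scatter)): it is the step of chloro in place of hydrogen on a saturated chain carbon, two bonds along the chain from a carbonyl carbon, and it is modest, while compound 2 stays within the scatter of both compound 1 and compound 3. No measurement is available that could explain either step.

On these data alone, what an amine, a carboxylic acid or a longer chain on this carbonyl carbon would do remains open, as does whether any group here could move the number far from the values of these three compounds. All three values also come from one cell line, so whether these small differences would hold in other cells cannot be said from the compounds shown.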